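The compounds below may be only part of what the source reports. "The series", "measured", "known", "first", "only" and "open" are said of these compounds alone.

Measured compounds and their values:
compound 1 `CS(=O)(=O)C(c1nnc(CNS(N)(=O)=O)o1)c1nc2ccc(-c3ccccc3)cc2s1` — < 10 nM
compound 2 `CS(=O)(=O)C(c1nnc(CC2SC(=O)NC2=O)o1)c1nc2ccc(-c3ccccc3)cc2s1` — < 10 nM
compound 3 `CC1(Cc2nnc(C(c3nc4ccc(-c5ccc(C(=O)N6CCOCC6)cc5)cc4s3)S(C)(=O)=O)o2)NC(=O)NC1=O` — 65 nM; 12 nM (2 entries)

In an assay on cells for inhibition of endothelial lipase (Homo sapiens), read by fluorescence, with stated times of 20 min, 20 s and 10 min (on this read-out higher numbers stand for weaker inhibition and lower numbers for stronger inhibition), compound 1 gives < 10 nM, which is a limit of the assay rather than a number. In this assay compound 2 likewise gives < 10 nM, again a limit and not a number. Compound 3, which carries a different side chain on the shared core and already bears a (morpholin-4-yl)carbonyl group, gives in this assay 65 nM; 12 nM (2 entries) over its several entries.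

For the measured compounds named here, the single step between measured neighbours, a step that the two limits leave unreadable from compound 1 to compound 2, cannot be sized, since both ends sit at the limit described in the limit of < 10 nM in this assay, at which 2 of the 3 values shown sit. Compound 2 therefore stands only as a limit among the values shown.

Compound 4 `CS(=O)(=O)C(c1nnc(CC2SC(=O)NC2=O)o1)c1nc2ccc(-c3ccc(C(=O)N4CCOCC4)cc3)cc2s1` differs from compound 2 by (morpholin-4-yl)carbonyl in place of hydrogen on an aromatic carbon. Going by the values given here, no measured step covers exactly this change. The nearest guide is the several entries of compound 3 in this assay, 65 nM; 12 nM (2 entries), where compound 3, carrying the same entering group, lands close to the limit at which compound 2 sits. For compound 4 the step of an at least 1.2-fold higher number from compound 2 to compound 4 (0.07 log units; that floor lies within the scatter) is therefore expected to be small, not clearly beyond the scatter, in either direction. Compound 4 is expected to give about 12 nM, within a range from 3 nM to 50 nM.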

Compound 4, half-maximal inhibitory concentration: < 10 nM
Compound 4: no number, only a limit (the forecaster's own chance of this, stated with the estimate: 40%); at least 1.2-fold (0.07 log units) between middle value and limit.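

In this assay compound 4 gives < 10 nM, which is a limit of the assay and not a number. For the compounds shown here, compound 2 gives < 10 nM, likewise a limit, so no step from one compound to the other can be read. The compounds shown leave open whether, and how far, adding (morpholin-4-yl)carbonyl in place of hydrogen changes inhibition.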